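This account rests on a few compounds, and the source may have more. Where it says the series, first, only, none or still open, it means among the compounds named here.

Compound 1 `O=C(N/N=C/c1ccc(Cl)cc1)c1cccnc1Nc1cccc(C(F)(F)F)c1`: 67.2%
Compound 2 `COc1ccc(/C=N/NC(=O)c2cccnc2Nc2cccc(C(F)(F)F)c2)cc1`: 59.4%
Compound 3 `CNc1ncccc1C(=O)N/N=C/c1cccc(Cl)c1`: 68.6%

All three compounds were tested in a functional assay on the whole organism (strain Wistar) for inhibition, with Rattus norvegicus as the target, read by paw edema, with a stated time of 1 h, at a dose of 10 mg/kg by the intraperitoneal route; a higher number here means more inhibition at the dose given (going by the name of the read-out), a lower number less inhibition. In that test compound 1 gives 67.2%, compound 2 gives 59.4%, and compound 3 gives 68.6%. The three numbers lie close together, and no gap between any two of them is larger than the usual scatter of repeated measurements, so the numbers of the three can only be called level with one another.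

Compound 1 and compound 2 share one core and differ in a single place: methoxy in place of chloro on an aromatic carbon. In this assay this change made a step of a number 7.8 percentage points lower from compound 1 to compound 2 (within the scatter).

Compound 3 rests on a different core; how the two cores differ is not broken down here. Compound 4 `CNc1ncccc1C(=O)N/N=C/c1cccc(OC)c1` has not yet been measured. It differs from compound 3 in one place: methoxy in place of chloro on an aromatic carbon. For the measured compounds named here, this is the same kind of change as the one from compound 1 to compound 2, but not the same: in the first pair the group sits para to a large group, in the second it sits meta to a large group.

The step from compound 3 to compound 4 in this assay is expected to be about a number 7.6 percentage points lower from compound 3 to compound 4 (within the scatter), because the same kind of change earlier gave a number 7.8 percentage points lower from compound 1 to compound 2 (within the scatter). Compound 4 is therefore estimated to give 61%, within a likely range from 49% to 72%.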

Compound 4, a percentage reported as inhibition, in the whole organism at one dose (the size of the read-out at that dose, not a potency): 64.6%
The estimate for compound 4 lay 3.6 percentage points below the measured number; the measured number falls inside the stated range.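

In this assay, putting methoxy in place of chloro on the core of compound 3 gave a step of a number 4 percentage points lower from compound 3 to compound 4 (within the scatter), and the same swap had been made earlier on the other core. Set side by side, the two steps cannot be told apart, so what was seen on one core is consistent with what was seen on the other: the same change on two cores in this assay, a number 7.8 percentage points lower (within the scatter) from compound 1 to compound 2 and a number 4 percentage points lower (within the scatter) from compound 3 to compound 4, 3.8 percentage points apart, within the scatter of two such steps. For the compounds shown here, this does not prove that the change carries over reliably from core to core, or even that it has a real effect, since each step on its own lies within the scatter, only two pairs are available, the group does not sit in the same place on the ring in the two pairs, and each number comes from a single dose rather than from a measure of potency.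

The compounds shown leave open whether any other group at these places on the ring would separate itself from chloro and methoxy, for example an amine, a carboxylic acid or a longer chain such as ethoxy. They also leave open whether the two cores would still behave alike with a change large enough to stand clear of the scatter.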